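The source may report more compounds than this note shows. Statements on the series, on what has been measured and on what is new or still open speak of the compounds shown alone.

Measured so far:
Compound 1 `COc1ccc(-c2nc3sc(-c4ccccc4)cn3n2)cc1`: 14%
Compound 2 `Clc1ccc(-c2cn3nc(-c4ccccc4)nc3s2)cc1`: 20%

In a functional assay on NCI-H322M cells (Homo sapiens) for inhibition, read by sulforhodamine B assay, with a stated time of 48 h, tested at 10 uM (on this read-out lower numbers stand for less inhibition of growth and higher numbers for more inhibition of growth at the one concentration tested), compound 2 gives 20%. Its only comparator, compound 1, gives 14%, and the two values lie within the scatter of each other. Both values sit toward the low end of the scale, and two compounds establish no trend.

The next compound is compound 3 `COc1ccc(-c2nc3sc(-c4ccc(Cl)cc4)cn3n2)cc1`. It differs from compound 2 by a methoxy in place of hydrogen on an aromatic carbon, para to a large group: methoxy in place of hydrogen on an aromatic carbon.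

For the measured compounds named here, no measured pair differs in one place, so this change has no direct precedent here. Going by the values given here, the only guide is that compound 1, which also carries a methoxy, gives 14% in this assay. That value offers no reason to expect a marked gain or loss relative to compound 2. No shift beyond the scatter is therefore expected in either direction. The estimated change is small, a number 2 percentage points higher from compound 2 to compound 3 (within the scatter).

For compound 3 the expected value is 22%, with an estimated range of 8% to 40%.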

Compound 3, percent growth inhibition at one concentration: 82.2%
The estimate for compound 3 lay 60.2 percentage points below the measured number, and the stated range ends below it.
By their numbers in this assay, from the lowest: compounds 1 and 2 (each within the scatter of the next); then compound 3.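

In this assay, for the compounds shown here, methoxy in place of hydrogen on an aromatic carbon, para to a large group, is the first single change to move the read-out beyond the scatter: a number 62.2 percentage points higher from compound 2 to compound 3 (beyond the scatter). The matching single change on the other side of the molecule, chloro in place of hydrogen on an aromatic carbon, gives a step of similar size: a number 68.2 percentage points higher from compound 1 to compound 3 (beyond the scatter). Thus compound 3, which carries both groups, stands well clear of the two compounds that each carry only one of them, and no available measurement explains this jump.

The compounds shown do not tell whether either group gives any gain on a core without the other, since each step here ends at compound 3 and neither starts from a compound lacking both groups. Also open, as far as these compounds go, is whether the methoxy step is specific to methoxy or would carry over to an ethoxy, a hydroxyl or an amine at the same place, and whether bromo or fluoro could replace the chloro.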